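Replacing the aminophenyl cap with a saturated chain

This account rests on a few compounds, and the source may have more. Where it says the series, first, only, none or still open, it means among the compounds named here.

The series shares the core of compound 1, `O=c1[nH]c(=O)n([C@H]2C[C@H](O)[C@@H](CO)O2)cc1C#CC#Cc1ccccc1`, and in a physicochemical assay for lipophilicity (on this read-out lower numbers stand for lower lipophilicity and higher numbers for higher lipophilicity), compound 1 gives 0.96. Compound 2, `Nc1ccc(C#CC#Cc2cn([C@H]3C[C@H](O)[C@@H](CO)O3)c(=O)[nH]c2=O)cc1`, adds an amino group on the aromatic ring, and in this assay compound 2 gives 0.13, the lowest of the three numbers. Compound 3, `O=c1[nH]c(=O)n([C@H]2C[C@H](O)[C@@H](CO)O2)cc1C#CC#Cc1ccc(OC(F)(F)F)cc1`, in this assay gives 2.39. The measured steps are a number 0.83 log units lower from compound 1 to compound 2 (beyond the scatter), a number 2.26 log units higher from compound 2 to compound 3 (beyond the scatter) and a number 1.43 log units higher from compound 1 to compound 3 (beyond the scatter).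

Compound 4, `O=c1[nH]c(=O)n([C@H]2C[C@H](O)[C@@H](CO)O2)cc1C#CC#CCC1CCCC1`, is the next step from compound 2: cyclopentylmethyl in place of 4-aminophenyl on a triple-bonded carbon. Of the measured steps, the loss of the amino group is covered in reverse by a number 0.83 log units lower from compound 1 to compound 2 (beyond the scatter), a modest step. Among the compounds with values here, no measured pair shows a five-membered non-aromatic ring in place of the aromatic one, so that part rests on the count alone: the entering group has no hydrogen-bond donors or acceptors, where the leaving group has one of each. The expected step in this assay is a number 1.47 log units higher from compound 2 to compound 4 (beyond the scatter), a rise beyond the scatter. For compound 4 the estimate is 1.6, within a range of 0.9 to 2.3.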

Compound 4, partition coefficient: 1.43
Compound 4: middle estimate off by 0.17 log units, on the high side, within the range that was stated.
By their numbers in this assay, from the lowest: compound 2; then compound 1; then compound 4; then compound 3.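

In this assay, cyclopentylmethyl in place of 4-aminophenyl gives a number 1.30 log units higher from compound 2 to compound 4 (beyond the scatter) and cyclopentylmethyl in place of phenyl gives a number 0.47 log units higher from compound 1 to compound 4 (beyond the scatter) for this triple-bonded carbon. The earlier steps shown here changed only a substituent on the aromatic ring, whereas these replace the ring itself and show that a non-aromatic cap at this place can give a number higher than that of the unsubstituted phenyl cap in compound 1. No supporting data explain the size of either step.

From the compounds shown here alone, compound 4 changes ring size, ring type and the link to the triple-bonded carbon at once, so the share of each stays open; a cyclohexyl cap or a straight pentyl chain would help separate them. Also open, going by these compounds, is whether an amine on the cyclopentyl ring would lower the number, as the amino group does on the phenyl ring.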